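Allylating the hydroxy group of compound 1

A few compounds are considered here, and "the series" means these few. Any claim that something is new, unique, unknown or untested is made for them only; others in the source may bear on it.

Values in a functional assay on Hep cells (Homo sapiens) for cytotoxicity, read by sulforhodamine B assay, with a stated time of 48 h; a lower number here means a stronger inhibitor, a higher number a weaker inhibitor:
- compound 1 `O=C(c1cccnc1)c1cc(Cl)cc(Cl)c1O`: 27000 nM
- compound 2 `O=C(c1cccnc1)c1cccc(Cl)c1O`: 28000 nM

In this assay, compound 1 and compound 2 lie within the scatter of each other, so the two measurements give no real order. The next change leads to compound 3 `C=CCOc1c(Cl)cc(Cl)cc1C(=O)c1cccnc1`: allyl in place of hydrogen on an oxygen on an aromatic ring. This is allyl in place of hydrogen on an oxygen on an aromatic ring, or hydroxy to allyloxy. Going by the values given here, the only measured step is a 1.0-fold higher number from compound 1 to compound 2 (0.02 log units; within the scatter), with hydrogen in place of chloro on an aromatic carbon. Among the compounds with values here, it bears only indirectly, since it leaves that oxygen unchanged, and no measured compound alters the hydroxy group. No step beyond the scatter is therefore expected in this assay, and no direction can be favoured. The estimated step is a 1.1-fold lower number from compound 1 to compound 3 (0.03 log units; within the scatter). For compound 3 the estimated value is 25000 nM, with an expected range of 9000 nM to 60000 nM.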

Compound 3, half-maximal inhibitory concentration: > 100000 nM
Compound 3: no number, only a limit; the forecaster's own chance of this, stated with the estimate: 15%; middle value at least 4.0-fold (0.60 log units) away from the limit.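

Hydroxy to allyloxy is the first change in the series whose effect in this assay lies beyond the scatter: an at least 3.7-fold higher number from compound 1 to compound 3 (0.56 log units; beyond the scatter). The loss of chloro on an aromatic carbon gave no such separation, a 1.0-fold higher number from compound 1 to compound 2 (0.02 log units; within the scatter), so the oxygen on the aromatic ring is the one place shown where a change registers in the read-out. Compound 3 gives > 100000 nM, which is a limit of the assay and not a number, and the full size of the step stays unread: the limit of > 100000 nM in this assay, at which 1 of the 3 values shown sits.

The compounds shown leave open whether the shift belongs to allyl in particular or would follow from any group on that oxygen, such as methyl or a longer chain. Also open, from the compounds shown here alone, is whether an amine in place of the hydroxy group would keep the number close to that of compound 1.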